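An Allyloxy Chain End on Compound 1

The source may report more compounds than this note shows. Statements on the series, on what has been measured and on what is new or still open speak of the compounds shown alone.

In a functional assay on T98G cells (Homo sapiens) for inhibition, read by colorimetric assay and MTT assay, with a stated time of 72 h (on this read-out higher numbers stand for weaker inhibition and lower numbers for stronger inhibition), compound 1 `C=CCCCCOc1ccccc1-c1cnc(OCCCCC=C)n1C` gives 4000 nM. Compound 2 `C=CCCCCOc1ncc(-c2ccccc2OC)n1C` gives 5000 nM, and compound 3 `C=CCCCCOc1ncc(-c2ccc(Cl)cc2OC)n1C` gives 67000 nM. Compound 1 therefore shares the low end of these three numbers with compound 2. Compound 4 `C=CCCCCOc1ccccc1-c1cnc(OCCOCC=C)n1C` alters one chain of compound 1: allyloxy in place of but-3-en-1-yl on a saturated chain carbon, two bonds along the chain from an oxygen on an aromatic ring. The nearest evidence is another chain edit, a 1.3-fold higher number from compound 1 to compound 2 (0.10 log units; within the scatter). The remaining step, a 13-fold higher number from compound 2 to compound 3 (1.13 log units; beyond the scatter), is large but adds chloro on an aromatic carbon, not on a chain. Among the measured compounds shown here, no measured compound carries an allyloxy group, so this comparison is only indirect. The expected change is small, a 1.5-fold higher number from compound 1 to compound 4 (0.18 log units; within the scatter). The estimate for compound 4 is 6000 nM, with an expected range of 2500 nM to 15000 nM.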

Compound 4, half-maximal inhibitory concentration: 65000 nM
Beside the measured number, compound 4's estimate is 11-fold (1.03 log units) below it; the whole stated range lies below it.
By their numbers in this assay, from the lowest: compounds 1 and 2 (each within the scatter of the next); then compounds 4 and 3 (each within the scatter of the next).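

Among the compounds shown here, this chain position tolerates less than the earlier compounds suggested. Allyloxy in place of but-3-en-1-yl keeps the heavy-atom count, exchanges one carbon for an oxygen and adds one hydrogen-bond acceptor, yet it gives a 16-fold higher number from compound 1 to compound 4 (1.21 log units; beyond the scatter) in this assay. The earlier chain edit, a 1.3-fold higher number from compound 1 to compound 2 (0.10 log units; within the scatter), stayed within the scatter, so a chain change at this end of the molecule can be either silent or large, and no available evidence explains this loss of inhibition.

Still open, from the compounds shown here alone, is whether an amine or a carboxylic acid at this place would behave like allyloxy. It is also unknown whether a longer all-carbon chain would keep the inhibition of compound 1.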